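Replacing 4-bromophenoxy in the series: expectation for compound 3

The source may report more compounds than this note shows. Statements on the series, on what has been measured and on what is new or still open speak of the compounds shown alone.

Compound 1 `COC(=O)c1oc2ccccc2c1NC(=O)CSc1ccc([N+](=O)[O-])cc1` gives 532 nM
Compound 2 `COC(=O)c1oc2ccccc2c1NC(=O)COc1ccc(Br)cc1` gives 1180 nM

In a functional assay (Cardiac muscle cell, Rattus norvegicus, strain Sprague-Dawley) for inhibition, read by LDH release, with a stated time of 6 h (on this read-out lower numbers stand for an effect already at smaller amounts and higher numbers for an effect only at larger amounts of compound), the two measured compounds differ beyond the scatter. Compound 2 stands at the higher of the two numbers (1180 nM) and compound 1 at the lower (532 nM). Compound 3 `COC(=O)c1oc2ccccc2c1NC(=O)CCSc1ccccn1` carries ((pyridin-2-yl)sulfanyl)methyl in place of 4-bromophenoxy on a saturated chain carbon bound to a carbonyl carbon. Among the compounds with values here, no measured pair isolates this change. No step beyond the scatter is expected in this assay and the estimated 1.5-fold lower number from compound 2 to compound 3 (0.17 log units; within the scatter) stays within it. For compound 3 the estimate is 800 nM (expected range 250 nM to 2500 nM).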

Compound 3, half-maximal effective concentration: 929 nM
Estimate against measurement, compound 3: 1.2-fold (0.06 log units) below, within the range that was stated.
By their numbers in this assay, from the lowest: compounds 1, 3 and 2 (each within the scatter of the next, the first and the last beyond it).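

In this assay the exchange of 4-bromophenoxy for ((pyridin-2-yl)sulfanyl)methyl on a saturated chain carbon bound to a carbonyl carbon gives a 1.3-fold lower number from compound 2 to compound 3 (0.10 log units; within the scatter) at this place. This position therefore accepts an aromatic ring with 1 hetero atom in place of a ring of carbon only, with no step beyond the scatter. Nothing available explains this result.

Still open, from the compounds shown here alone, is whether a basic amine or a carboxylic acid at this place stays within the scatter of compound 2. A longer chain carrying the pyridin-2-yl ring is also untested among the compounds shown.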